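Methoxy for methyl on the bromo-bearing quinolinone core

This account rests on a few compounds, and the source may have more. Where it says the series, first, only, none or still open, it means among the compounds named here.

Measured compounds in a functional assay on NCI-H460 cells (Homo sapiens) for cytotoxicity, read by MTT assay, with a stated time of 48 h; on this read-out higher numbers stand for weaker inhibition and lower numbers for stronger inhibition:
- compound 1, `Cc1ccc2[nH]c(=O)c(-c3nc4cc(Cl)ccc4[nH]3)cc2c1`: 36500 nM
- compound 2, `Cc1ccc2[nH]c(=O)c(-c3nc4cc(Br)ccc4[nH]3)cc2c1`: > 100000 nM, a limit of the assay
- compound 3, `Cc1ccc2[nH]c(=O)c(-c3nc4cc(F)ccc4[nH]3)cc2c1`: > 100000 nM, a limit of the assay

Compound 2 stands at the limit of this assay and gives no number, a position shared by two of the three values shown (the limit of > 100000 nM in this assay, at which 2 of the 3 values shown sit). Among the measured compounds shown here, compound 1 is the only member with a readable value, and the steps of an at least 2.7-fold higher number from compound 1 to compound 2 (0.43 log units; beyond the scatter) and an at least 2.7-fold higher number from compound 1 to compound 3 (0.43 log units; beyond the scatter) both move away from it to the limit; the step that the two limits leave unreadable from compound 2 to compound 3 cannot be read between two limits.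

Compound 4, `COc1ccc2[nH]c(=O)c(-c3nc4cc(Br)ccc4[nH]3)cc2c1`, is not yet measured. It differs from compound 2 in one place: methoxy in place of methyl on an aromatic carbon. For the measured compounds named here, none of the measured steps touches this position; all three vary the halogen on the other ring, so no step bears directly on the change. Compound 2 sits at the limit, and the step of a number no higher from compound 2 to compound 4 (the limit leaves the size open) is therefore expected only to leave compound 4 near that limit as well. Compound 4 is estimated at 100000 nM in this assay, with a range from 40000 nM to 300000 nM, and is expected most likely to return a limit rather than a number.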

Compound 4, half-maximal inhibitory concentration: > 100000 nM
Compound 4: no number, only a limit; the forecaster's own chance of this, stated with the estimate: 70%; the middle value sits exactly at the limit.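

Compound 2 and compound 4 both stand at a limit in this assay, so no step can be read for methoxy in place of methyl: the limit of > 100000 nM in this assay, at which 3 of the 4 values shown sit.
The compounds shown leave open how methoxy compares with methyl on the shared core.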